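Pendant aryl variation on the shared pyrazolopyridine series

The compounds below may be only part of what the source reports. "The series", "measured", "known", "first", "only" and "open" are said of these compounds alone.

Of the compounds shown here, three have been read in an assay for binding affinity to dual specificity mitogen-activated protein kinase kinase 4 (Homo sapiens), read by KINOMEscan, tested at 100 nM (on this read-out lower numbers stand for a stronger effect and higher numbers for a weaker effect at the one concentration tested), and they differ only in the aryl group on the shared core. Compound 1 `CCCS(=O)(=O)Nc1ccc(F)c(C(=O)c2n[nH]c3ncc(-c4cccc(Cl)c4)cc23)c1F` gives 40%. Compound 2 `CCCS(=O)(=O)Nc1ccc(F)c(C(=O)c2n[nH]c3ncc(-c4ccccc4F)cc23)c1F` gives 2%. Compound 3 `CCCS(=O)(=O)Nc1ccc(F)c(C(=O)c2n[nH]c3ncc(-c4cccc(F)c4)cc23)c1F` gives 8.2%. Compound 3 therefore stands second highest of the three numbers: its nearest neighbour is compound 2, separated by a number 6.2 percentage points higher from compound 2 to compound 3 (within the scatter), and its furthest is compound 1, separated by a number 31.8 percentage points lower from compound 1 to compound 3 (beyond the scatter). The other step, a number 38 percentage points lower from compound 1 to compound 2 (beyond the scatter), is likewise large.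

Compound 4 `CCCS(=O)(=O)Nc1ccc(F)c(C(=O)c2n[nH]c3ncc(-c4ccccc4C)cc23)c1F` is the next member and has not yet been measured. It differs from compound 3 by 2-methylphenyl in place of 3-fluorophenyl on an aromatic carbon. Going by the values given here, two measured steps bear on it. The move from the 3-fluorophenyl to the 2-fluorophenyl, a number 6.2 percentage points higher from compound 2 to compound 3 (within the scatter) read in reverse, shows that shifting the substituent around the ring changed little. The move from chloro to fluoro, a number 31.8 percentage points lower from compound 1 to compound 3 (beyond the scatter), shows that the identity of the substituent mattered a great deal. Among the compounds with values here, a methyl group has no measured counterpart in this set, so its effect is open. On balance a small step in this assay is expected for compound 4, a number 6.8 percentage points higher from compound 3 to compound 4 (within the scatter), with a wide allowance toward higher numbers because of a number 31.8 percentage points lower from compound 1 to compound 3 (beyond the scatter). The estimate for compound 4 is 15%, with a range from 3% to 40%.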

Compound 4, a percentage reported as activity, at one concentration (the size of the read-out at that concentration, not a potency): 7%
Beside the measured number, compound 4's estimate is 8 percentage points above it, and the stated range covers the measured number.
By their numbers in this assay, from the lowest: compounds 2, 4 and 3 (each within the scatter of the next); then compound 1.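

In this assay, a methyl on the pendant ring reads like a fluoro: the record holds a number 1.2 percentage points lower from compound 3 to compound 4 (within the scatter) and a number 5 percentage points higher from compound 2 to compound 4 (within the scatter), so the two fluorophenyl compounds and the 2-methylphenyl of compound 4 form one group. Going by these compounds alone, the earlier compounds allowed the reading that fluorine itself was needed for a low number, and compound 4, whose pendant group holds carbon only, rules that out, while the record of a number 33 percentage points lower from compound 1 to compound 4 (beyond the scatter) leaves compound 1 with its 3-chlorophenyl as the only member set apart among the four. No measurement here accounts for why the chlorine-bearing compound stands apart.

On these data alone, what remains open is whether the number of compound 1 belongs to chloro as such or to chloro at that ring location, a question that 2-chlorophenyl and 3-methylphenyl analogues would settle by pairing each substituent with the other location. Whether the low numbers hold for larger or heteroatom-bearing groups on this ring, such as methoxy, an amine or a carboxylic acid, also cannot be told from these four compounds.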